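Benzamide-sulfonamide series: ortho substituent on the sulfonyl ring

A few compounds are considered here, and "the series" means these few. Any claim that something is new, unique, unknown or untested is made for them only; others in the source may bear on it.

Measured so far in an assay on MDA-MB-231 cells for displacement of a labelled ligand from C-X-C chemokine receptor type 4 (Homo sapiens), read by fluorescence and microscopy, with stated times of 10 min and 30 min; on this read-out lower numbers stand for an effect already at smaller amounts and higher numbers for an effect only at larger amounts of compound:
compound 1 `O=C(NCc1ccc(CNS(=O)(=O)c2ccccc2F)cc1)c1cccnc1`, 100 nM;
compound 2 `COc1ccccc1C(=O)NCc1ccc(CNS(=O)(=O)c2ccccc2C)cc1`, 1000 nM;
compound 3 `Cc1ccccc1C(=O)NCc1ccc(CNS(=O)(=O)c2ccc([N+](=O)[O-])cc2)cc1`, 100 nM.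

Compound 2 gives the highest of the three numbers in this assay. Compound 1 and compound 3 each sit a long way lower, and both of those gaps lie beyond the usual scatter, so on the numbers shown compound 2 is the weakest of the measured set. Compound 1 and compound 3 differ from compound 2 in more than one place, so none of these pairs gives a clean single step and no cause can be read from them.

Compound 4 `COc1ccccc1C(=O)NCc1ccc(CNS(=O)(=O)c2ccccc2Cl)cc1` is not yet measured. It differs from compound 2 in one place: chloro in place of methyl on an aromatic carbon. Among the measured compounds shown here, no measured pair isolates this change. The expectation for the step of a 1.7-fold lower number from compound 2 to compound 4 (0.22 log units; within the scatter) is a small move toward a lower number, most likely not beyond the scatter. Compound 4 is therefore estimated at 600 nM, with a plausible range from 150 nM to 2000 nM.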

Compound 4, effective concentration (reported as EC, without a stated level of effect): 100 nM
The estimate for compound 4 lay 6.0-fold (0.78 log units) above the measured number, outside the stated range (below it).
By their numbers in this assay, from the lowest: compounds 1, 3 and 4 (each within the scatter of the next); then compound 2.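

In this assay, among the compounds shown here, the change from 2-methylphenyl to 2-chlorophenyl on the sulfonyl gives a 10-fold lower number from compound 2 to compound 4 (1.00 log units; beyond the scatter), the first single-place comparison and one that lies beyond the scatter. This position, ortho to a large group, is therefore not indifferent to its substituent: exchanging one heavy atom for another, with no change in the counted hydrogen-bond donors, hydrogen-bond acceptors or net charge, is enough to move the number. No measurement shown accounts for the size or direction of this step.

Going by these compounds, with only methyl and chloro compared here, it remains open whether a bromo or a nitrile at this position would read like chloro or like methyl. On these data alone, it also remains open whether the same exchange gives a similar step when the other end of the molecule carries a different amide group.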